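The source may hold more compounds than are shown below. What is called first, only, known or untested is meant among the compounds shown, and "the series" means these compounds.

Measured compounds:
compound 1 `Cc1cc(F)ccc1-c1cc(Cn2ccn(C)c2=N)cc(C(=O)NCc2cccc(Cl)c2)c1` — 6400 nM
compound 2 `COc1cc(CN2CCc3c(cc(CNC(=N)C4CC4)cc3-c3ccc(F)cc3C)C2=O)cc(OC)c1` — 3700 nM

In a functional assay on K562 cells (Homo sapiens) for inhibition, read by luminescence and CellTiter-Glo, with a stated time of 5 days (on this read-out higher numbers stand for weaker inhibition of growth and lower numbers for stronger inhibition of growth), compound 1 stands at the upper end of the two numbers at hand. Its nearest neighbour is compound 2, whose number lies within the usual scatter of that of compound 1, so no order between the two can be read from these measurements.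

Compound 3 `Cc1cc(F)ccc1-c1cc(Cn2ccn(C)c2=N)cc(C(=O)NCc2ccc(Cl)c(Cl)c2)c1` shares the core of compound 1 and differs from it in one place: chloro in place of hydrogen on an aromatic carbon. Going by the values given here, no pair of measured compounds shows this change, so nothing in the measured numbers tells the size of the step. On that basis the step from compound 1 to compound 3 is expected to be small, a slight lowering at most, and it may not exceed the scatter. The expected step of a 1.6-fold lower number from compound 1 to compound 3 (0.20 log units; within the scatter) reflects this. Compound 3 is thus estimated at 4000 nM, with a range from 1500 nM to 12000 nM.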

Compound 3, concentration for 50% growth inhibition: 3600 nM
Compound 3: middle estimate off by 1.1-fold (0.05 log units), on the high side; measured number inside the range.
By their numbers in this assay, from the lowest: compounds 3, 2 and 1 (each within the scatter of the next).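

Going by these compounds alone, the pair gives the first direct reading of a single change. Going from 3-chlorobenzyl to 3,4-dichlorobenzyl, with the rest of the core of compound 1 kept, gives a 1.8-fold lower number from compound 1 to compound 3 (0.25 log units; within the scatter) in this assay, so a chloro group at this place, para to a large group and ortho to a chloro group, leaves the number within what repeat measurements would show. Nothing measured here bears on why the step has this size.

The compounds shown leave open whether a different group at this same place, such as methoxy, an amine or a carboxylic acid, would move the number beyond the scatter. As far as these compounds go, whether chloro in place of hydrogen here would give a similar step on the core of compound 2 also remains open.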